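The source may report more compounds than this note shows. Statements on the series, on what has been measured and on what is new or still open speak of the compounds shown alone.

Working notes on the series. Going by the values given here, compound 2 `COc1cc(-c2nc3cc(/C=C4\SC(=O)N(CC(=O)N5CCCCC5)C4=O)ccc3[nH]2)cc(OC)c1OC` holds the lowest of the two numbers so far in a functional assay on A549 cells (Homo sapiens) for inhibition, read by MTT assay, with a stated time of 48 h; on this read-out higher numbers stand for weaker inhibition and lower numbers for stronger inhibition: compound 2 gives 980 nM. Its nearest neighbour is compound 1 `COc1cc(-c2nc3cc(/C=C4\SC(=O)N(CC(=O)N5CCOCC5)C4=O)ccc3[nH]2)cc(OC)c1OC`, which in this assay gives 2930 nM. Among the compounds with values here, the one step measured so far, a 3.0-fold lower number from compound 1 to compound 2 (0.48 log units; beyond the scatter), consists of swapping morpholin-4-yl for piperidin-1-yl on the carbonyl carbon.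

Compound 3 `COc1cc(-c2nc3cc(/C=C4\SC(=O)N(CC(=O)N5CCCC5)C4=O)ccc3[nH]2)cc(OC)c1OC` is not yet measured. It differs from compound 2 by pyrrolidin-1-yl in place of piperidin-1-yl on a carbonyl carbon, so the six-membered non-aromatic ring with one hetero atom is replaced by a five-membered one, with no change in the count of hydrogen-bond donors or acceptors. Within the data shown here, only the step from compound 1 to compound 2 bears on this position, and it concerned a different exchange at the same carbonyl carbon; nothing measured so far speaks to shrinking the ring. The expectation for this assay is therefore a step no larger than the scatter, in either direction, with a slight lean toward a higher number. Compound 3 is estimated at 1300 nM with a range from 500 nM to 3500 nM, a step of a 1.3-fold higher number from compound 2 to compound 3 (0.12 log units; within the scatter) expected from compound 2.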

Compound 3, half-maximal inhibitory concentration: 910 nM
Compound 3: middle estimate off by 1.4-fold (0.15 log units), on the high side; the measured number falls inside the stated range.
By their numbers in this assay, from the lowest: compounds 3 and 2 (each within the scatter of the next); then compound 1.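

In this assay the size of the saturated ring on this carbonyl carbon does not separate the two compounds that carry only carbon besides the ring nitrogen: pyrrolidin-1-yl in place of piperidin-1-yl gives a 1.1-fold lower number from compound 2 to compound 3 (0.03 log units; within the scatter) and so leaves the number where it was within the scatter. The exchange of morpholin-4-yl for pyrrolidin-1-yl gives a 3.2-fold lower number from compound 1 to compound 3 (0.51 log units; beyond the scatter) and stands close to the earlier 3.0-fold lower number from compound 1 to compound 2 (0.48 log units; beyond the scatter), so among these three compounds the step beyond the scatter appears only when morpholin-4-yl leaves, whichever of the two other rings enters. No measurement on hand accounts for either the flat step or the larger ones.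

The compounds shown leave open how the number responds on the same carbonyl carbon to an azepan-1-yl ring, a piperazin-1-yl ring or an open-chain dimethylamino group, any of which would show whether the flat response extends beyond the five- and six-membered rings. Also open, as far as these compounds go, is whether a longer chain in place of the methyl link in ((pyrrolidin-1-yl)carbonyl)methyl keeps the number of compound 3 at 910 nM or moves it.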